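Three Pyridyl Amides at the Assay Limit

This account rests on a few compounds, and the source may have more. Where it says the series, first, only, none or still open, it means among the compounds named here.

Three compounds share one core and differ only in the group on the amide-type nitrogen. Compound 1 `COc1ccc2nc(C)cc(OCC(=O)Nc3cc(F)cc(F)c3)c2c1` in a toxicity assay on HepG2 cells (Homo sapiens) for inhibition, read by CellTiter-Glo, with a stated time of 48 h (on this read-out higher numbers stand for weaker inhibition and lower numbers for stronger inhibition), gives > 100000 nM, which is a limit of the assay rather than a number. Compound 2 `COc1ccc2nc(C)cc(OCC(=O)Nc3ccccn3)c2c1` gives > 100000 nM, again a limit. Compound 3 `COc1ccc2nc(C)cc(OCC(=O)Nc3cccnc3)c2c1` gives > 100000 nM, also a limit. The steps a step that the two limits leave unreadable from compound 1 to compound 2, a step that the two limits leave unreadable from compound 1 to compound 3 and a step that the two limits leave unreadable from compound 2 to compound 3 cannot be sized since (the limit of > 100000 nM in this assay, at which 3 of the 3 values shown sit). Compound 4 `COc1ccc2nc(C)cc(OCC(=O)Nc3ccncc3)c2c1` differs from compound 3 by pyridin-4-yl in place of pyridin-3-yl on an amide-type nitrogen. No measured step can be read, so no step beyond the scatter is expected in this assay. Compound 4 is estimated at 150000 nM, between 100000 nM and 300000 nM, most probably reported again only as a limit. The expected step that the limit leaves unreadable from compound 3 to compound 4 is thus an estimate of no change.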

Compound 4, half-maximal inhibitory concentration: > 100000 nM
Compound 4: no number, only a limit; the forecaster's own chance of this, stated with the estimate: 90%; the middle value is on the limit's open side.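

Among these compounds, no step from compound 1, compound 2 or compound 3 to compound 4 can be read in this assay: the limit of > 100000 nM in this assay, at which 4 of the 4 values shown sit. The compounds shown leave open whether any group on the amide-type nitrogen would give a measurable value in this assay.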